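The compounds below may be only part of what the source reports. "The series", "measured", "known", "first", "only" and "open" are said of these compounds alone.

Measured so far:
compound 1, `COc1ccc(NC(=O)[C@H]2CCCCN2C(=O)C2(c3ccc(Cl)cc3)CCCC2)cc1`, gives 5.01 nM in an assay on isolated protein for inhibition of histone acetyltransferase p300 (Homo sapiens), with a stated time of 60 min; a higher number here means a weaker inhibitor, a lower number a stronger inhibitor
compound 2, `O=C(Nc1ccc2[nH]c(=O)[nH]c2c1)[C@H]1CCCN1C(=O)C1(c2cccc(Cl)c2)CCCC1`, gives 0.398 nM in this assay

Compound 2 has the lower of the two numbers, and compound 1 stands a good way apart from it, beyond the usual scatter, so compound 2 is the stronger inhibitor of the pair. The untested compound 3, `COc1ccc(NC(=O)[C@H]2CCCN2C(=O)C2(c3cccc(Cl)c3)CCCC2)nc1`, differs from compound 2 in one place: a group of 8 heavy atoms (6 carbon, 1 nitrogen, 1 oxygen; one six-membered aromatic ring with 1 hetero atom) in place of a group of 10 heavy atoms (7 carbon, 2 nitrogen, 1 oxygen; one five-membered aromatic ring with 2 hetero atoms, one six-membered aromatic ring of carbon only), on an amide-type nitrogen. Among the compounds with values here, no measured pair isolates this change, so the step can only be judged from compound 1, which also carries a methoxy-bearing aromatic ring on that nitrogen and gives 5.01 nM, though it differs from compound 2 elsewhere as well. The step of a 10-fold higher number from compound 2 to compound 3 (1.00 log units; beyond the scatter) is therefore expected to go toward a weaker inhibitor, by more than the scatter. Compound 3 is estimated at 4 nM, with a likely range from 1 nM to 16 nM.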

Compound 3, half-maximal inhibitory concentration: 2 nM
For compound 3 the middle estimate is 2.0-fold (0.30 log units) above the measured one, and the stated range covers the measured number.
By their numbers in this assay, from the lowest: compound 2; then compound 3; then compound 1.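

Within the data shown here, this is the first pair that isolates a change on the amide-type nitrogen. In this assay, replacing the group with a five-membered and a six-membered aromatic ring by 5-methoxypyridin-2-yl gives a 5.0-fold higher number from compound 2 to compound 3 (0.70 log units; beyond the scatter) and so costs inhibition beyond the scatter. Even so, compound 3 gives 2 nM with one aromatic ring and 0 hydrogen-bond donors on this nitrogen, so the larger group with its 2 hydrogen-bond donors is not needed for a low number, and no measurement here accounts for the step.

Several features change together in this swap, so the pair cannot show which of them sets the size of the step. Going by these compounds, how the number would respond to a plain phenyl ring, or to an amino group in place of the methoxy group on the pyridine, remains open.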